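The compounds below may be only part of what the source reports. "The series", "measured", "known", "first", "only" and "open" are said of these compounds alone.

Working notes on the series. In a functional assay on the whole organism (strain Wister albino) for inhibition, with Rattus norvegicus as the target, read by paw edema, with stated times of 1 h and 3 h, at a dose of 50 mg/kg by the intraperitoneal route (a lower number here means less inhibition, a higher number more inhibition at the dose given (going by the name of the read-out)), compound 1 `CN1C[C@@H](c2ccccc2)[C@@]2(Cc3ccccc3C2=O)[C@@]12C(=O)Nc1ccccc12` gives 42.5%. Going by the values given here, compound 2 `CN1C[C@@H](c2ccc(F)cc2)[C@@]2(Cc3ccccc3C2=O)[C@@]12C(=O)Nc1ccccc12` gives 21.1%, and the change of a number 21.4 percentage points lower from compound 1 to compound 2 (beyond the scatter) is the only measured step so far. Compound 3 `CN1C(=O)[C@@]2(c3ccccc31)N(C)C[C@@H](c1ccco1)[C@@]21Cc2ccccc2C1=O` gives 17.5%, the lowest of the three numbers shown, within the scatter of compound 2 but beyond it against compound 1. Compound 4 `CN1C(=O)[C@@]2(c3ccccc31)N(C)C[C@@H](c1ccc(F)cc1)[C@@]21Cc2ccccc2C1=O` is not yet measured; it differs from compound 3 by 4-fluorophenyl in place of furan-2-yl on a saturated ring carbon. The step from compound 1 to compound 2 bears only in part: it exchanges hydrogen for fluoro on an aromatic carbon rather than one ring for another, and compound 2 carries the same 4-fluorophenyl on a different core. A step of a number 2.5 percentage points higher from compound 3 to compound 4 (within the scatter) is expected, within the scatter. Compound 4 is estimated at 20%, in the range 8% to 34%.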

Compound 4, a percentage reported as inhibition, in the whole organism at one dose (the size of the read-out at that dose, not a potency): 26.9%
Beside the measured number, compound 4's estimate is 6.9 percentage points below it; measured number inside the range.
By their numbers in this assay, from the lowest: compounds 3, 2 and 4 (each within the scatter of the next); then compound 1.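

At the saturated ring carbon, 4-fluorophenyl in place of furan-2-yl gives a number 9.4 percentage points higher from compound 3 to compound 4 (within the scatter) in this assay and so shows no separation between these two aromatic rings at this position. With 4-fluorophenyl held fixed, methyl in place of hydrogen on the amide-type nitrogen in a ring gives a number 5.8 percentage points higher from compound 2 to compound 4 (within the scatter) and so this nitrogen also shows no step beyond the scatter. Nothing available explains either step.

Still open, on these data alone, is whether an amine or a carboxylic acid at this saturated ring carbon would give a step beyond the scatter. The same question stands for a longer chain on the amide-type nitrogen.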